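Adding methoxy to the phenyl ring of compound 3

The source may report more compounds than this note shows. Statements on the series, on what has been measured and on what is new or still open speak of the compounds shown alone.

Values in a functional assay on A549 cells (Homo sapiens) for inhibition, read by MTT assay, with a stated time of 48 h; a higher number here means a weaker inhibitor, a lower number a stronger inhibitor:
- Compound 1 `Cn1cc(NC(=O)c2cccc(NS(=O)(=O)c3ccccc3)c2)cn1`: > 100000 nM (a limit of the assay)
- Compound 2 `O=C(Nc1cnn(-c2ccccc2)c1)c1cccc(NS(=O)(=O)c2ccccc2)c1`: 26800 nM
- Compound 3 `O=C(Nc1cnn(-c2ccccc2)c1)c1cccc(NS(=O)(=O)c2ccc(Cl)cc2)c1`: 19300 nM

The value for compound 1 is a limit and not a number. Within the data shown here, only two exact numbers are therefore available, and compound 3 at 19300 nM cannot be separated from compound 2 at 26800 nM, since they lie within the usual scatter of each other.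

The next compound is compound 4 `COc1ccc(-n2cc(NC(=O)c3cccc(NS(=O)(=O)c4ccc(Cl)cc4)c3)cn2)cc1`. It has methoxy in place of hydrogen on an aromatic carbon, para to a large group, so phenyl becomes 4-methoxyphenyl (methoxy in place of hydrogen on an aromatic carbon).

Among the measured compounds shown here, two measured steps bear on this change. The first, an at least 3.7-fold lower number from compound 1 to compound 2 (0.57 log units; beyond the scatter), put phenyl in place of methyl on an aromatic nitrogen, which shows that the number can respond to a change at that part of the molecule. The second, a 1.4-fold lower number from compound 2 to compound 3 (0.14 log units; within the scatter), put chloro in place of hydrogen on an aromatic carbon and stayed within the scatter. Neither step tests methoxy itself, so no change beyond the scatter is expected in this assay.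

The expected step is a 1.2-fold lower number from compound 3 to compound 4 (0.08 log units; within the scatter). For compound 4 the estimate is 16000 nM, with an expected range from 6500 nM to 40000 nM.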

Compound 4, half-maximal inhibitory concentration: 29700 nM
The estimate for compound 4 lay 1.9-fold (0.27 log units) below the measured number; the range from low to high includes it.
By their numbers in this assay, from the lowest: compounds 3, 2 and 4 (each within the scatter of the next). At a limit, above all of these: compound 1.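

Methoxy is the first group shown on the carbon ring attached to the aromatic nitrogen, and in this assay the result is a 1.5-fold higher number from compound 3 to compound 4 (0.19 log units; within the scatter). This position on that ring, para to a large group, therefore takes a methoxy group with no difference that can be told from the scatter, so the response seen earlier when phenyl replaced methyl on the nitrogen does not extend to this substitution on the phenyl ring. Compounds 2, 3 and 4 all give exact numbers that can be compared, and only compound 1 does not, as its value is a limit: the limit of > 100000 nM in this assay, at which 1 of the 4 values shown sits.

Going by these compounds, it remains open whether a different group at this position, such as an amine, a carboxylic acid or a longer chain like butoxy, would give a step beyond the scatter. The compounds shown also leave open whether methoxy would behave the same way at another carbon of this ring, or on a compound without the chloro group that compound 4 carries.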